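The source may report more compounds than this note shows. Statements on the series, on what has been measured and on what is new or still open speak of the compounds shown alone.

Compound 1 `Nc1ncnc2[nH]cc(-c3ccc(NC(=O)c4cn(CC5CCOCC5)cc(-c5ccc(F)cc5)c4=O)cc3)c12`, which carries a hydrogen on the aromatic nitrogen of its core, gives 0.2 nM in an assay on isolated protein for inhibition of tyrosine-protein kinase receptor UFO (Homo sapiens), read by ELISA; a lower number here means a stronger inhibitor, a higher number a weaker inhibitor. For the measured compounds named here, compound 2 `CCCn1cc(-c2ccc(NC(=O)c3cn(CC4CCOCC4)cc(-c4ccc(F)cc4)c3=O)cc2)c2c(N)ncnc21`, the propyl analogue, gives 1.8 nM and so stands as the higher of the two numbers measured so far, the step being a 9.0-fold higher number from compound 1 to compound 2 (0.95 log units; beyond the scatter). Compound 3 `CN(C)CCn1cc(-c2ccc(NC(=O)c3cn(CC4CCOCC4)cc(-c4ccc(F)cc4)c3=O)cc2)c2c(N)ncnc21` differs from compound 2 by dimethylamino in place of methyl on a saturated chain carbon, two bonds along the chain from an aromatic nitrogen. Going by the values given here, no measured pair shows this particular exchange; the only step recorded concerns what sits on the aromatic nitrogen at all, and it was modest. Since the chain is kept and only its far end changes, the expectation for compound 3 is a step of a 1.2-fold lower number from compound 2 to compound 3 (0.08 log units; within the scatter), which is within the scatter and so no clear movement in either direction. Compound 3 is therefore estimated at 1.5 nM, with a range from 0.5 nM to 5 nM.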

Compound 3, half-maximal inhibitory concentration: 2.8 nM
Compound 3: the middle estimate sits 1.9-fold (0.27 log units) below what was measured, and the stated range covers the measured number.
By their numbers in this assay, from the lowest: compound 1; then compounds 2 and 3 (each within the scatter of the next).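

In this assay, the exchange of methyl for dimethylamino on a saturated chain carbon, two bonds along the chain from an aromatic nitrogen, gives a 1.6-fold higher number from compound 2 to compound 3 (0.19 log units; within the scatter), so this added amine cannot be told apart from no change at all. Against the plain hydrogen of compound 1, the whole 2-(dimethylamino)ethyl group gives a 14-fold higher number from compound 1 to compound 3 (1.15 log units; beyond the scatter), so both chains shown on this nitrogen, propyl in compound 2 and 2-(dimethylamino)ethyl in compound 3, stand beyond the scatter from the hydrogen compound. No supporting measurement is available to explain these numbers.

The compounds shown leave open whether a carboxylic acid or morpholine in that place, or a longer chain, would give a similar number. They also leave open whether any group on this nitrogen could match the hydrogen of compound 1.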